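Benzyl ether variation on a pyrazole carboxylic acid antagonist

The source may hold more compounds than are shown below. What is called first, only, known or untested is meant among the compounds shown, and "the series" means these compounds.

Compound 1: `O=C(O)c1nn(Cc2cc(Br)ccc2OCc2ccccc2)cc1F`, 692 nM
Compound 2: `Cc1cc(C(=O)O)nn1Cc1cc(Br)ccc1OCc1ccc(Cl)cc1`, 8.71 nM

Two compounds carry a measurement in a functional assay on CHO-K1 cells for antagonist activity at prostaglandin E2 receptor EP1 subtype (Homo sapiens), read by FLIPR; a higher number here means a weaker inhibitor, a lower number a stronger inhibitor. Compound 1 gives 692 nM, while compound 2 gives 8.71 nM, the lowest number of the two; compound 1 lies well beyond the scatter above it. Compound 2 thus stands as the stronger inhibitor of this pair, though it differs from compound 1 in more than one place, so the two values alone do not tell which part of the structure accounts for the gap.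

Compound 3, `Cc1cc(C(=O)O)nn1Cc1cc(Br)ccc1OCc1cc(Cl)cc(Cl)c1`, keeps the core of compound 2 and changes only the group on the saturated chain carbon bound to an oxygen on the aromatic ring: 3,5-dichlorophenyl in place of 4-chlorophenyl on a saturated chain carbon bound to an oxygen on an aromatic ring. Among the measured compounds shown here, no measured pair shows the effect of this change. The author expects a step of a 1.7-fold higher number from compound 2 to compound 3 (0.24 log units; within the scatter) in this assay that remains within the usual scatter or goes slightly toward a weaker inhibitor. Compound 3 is therefore estimated at 15 nM, with a range from 4 nM to 55 nM.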

Compound 3, inhibition constant: 1120 nM
The estimate for compound 3 lay 75-fold (1.87 log units) below the measured number, outside the stated range (above it).
By their numbers in this assay, from the lowest: compound 2; then compounds 1 and 3 (each within the scatter of the next).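

In this assay, 3,5-dichlorophenyl in place of 4-chlorophenyl on a saturated chain carbon bound to an oxygen on an aromatic ring gives a 130-fold higher number from compound 2 to compound 3 (2.11 log units; beyond the scatter), a large step beyond the scatter and the only comparison among these compounds that differs in one place. Compound 1 and compound 2 differ in more than one place and could not isolate this position, whereas here the rest of the structure stays the same and the step belongs to this single exchange. The position is therefore highly sensitive to the chlorine pattern on this phenyl group, but nothing available explains the size of the step.

As far as these compounds go, what remains open is how a 3-chlorophenyl, a 3,4-dichlorophenyl or a 4-methoxyphenyl group would behave at this place, and thus whether the step follows the number of chlorine atoms or where they sit. From the compounds shown here alone, it is also open whether the same exchange would give a step of similar size on the core of compound 1, which carries a plain phenyl group here.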